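Cyclopentyl for butyl on the thioether: cytotoxicity notes

The source may hold more compounds than are shown below. What is called first, only, known or untested is meant among the compounds shown, and "the series" means these compounds.

Compound 1 `CCCCSc1nc(Cc2c(F)cccc2Cl)c(C)c(=O)[nH]1` and compound 2 `Cc1c(Cc2c(F)cccc2Cl)nc(SC2CCCC2)[nH]c1=O` share one core and differ only at the sulfur; the change is cyclopentyl in place of butyl on a sulfur. In an ADME assay on MT4 cells (Homo sapiens) for activation, read by MTT assay (on this read-out lower numbers stand for higher toxicity in this test and higher numbers for lower toxicity in this test), compound 1 gives a limit of > 73000 nM. In this assay compound 2 gives a limit of > 71000 nM. Within the data shown here, the step that the two limits leave unreadable from compound 1 to compound 2 therefore cannot be sized: both entries are limits, as recorded in the limit of > 73000 nM in this assay, at which 1 of the 3 values shown sits, and (the limit of > 71000 nM in this assay, at which 1 of the 3 values shown sits), so the pair says only that neither compound shows toxicity up to the concentrations tested.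

Compound 3 `CCCCSc1nc(C(C)c2c(F)cccc2Cl)c(CC)c(=O)[nH]1` carries a different core; how the core of compound 3 differs from the core of compound 1 is not broken down here. In this assay compound 3 gives a limit of > 3000 nM, as noted in the limit of > 3000 nM in this assay, at which 1 of the 3 values shown sits. Compound 4 `CCc1c(C(C)c2c(F)cccc2Cl)nc(SC2CCCC2)[nH]c1=O` is not yet measured. It differs from compound 3 by cyclopentyl in place of butyl on a sulfur, the same change at the same place as between compound 1 and compound 2.

Among the measured compounds shown here, the only precedent for this change left no readable movement. For the measured compounds named here, from compound 3 to compound 4 the expected step is a step that the limit leaves unreadable from compound 3 to compound 4, resting on the unreadable step that the two limits leave unreadable from compound 1 to compound 2 and on the fact that every value so far is a limit. For compound 4 in this assay the estimate is 30000 nM, within an expected range from 3000 nM to 100000 nM, with a strong likelihood that only a limit is reported again.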

Compound 4, half-maximal cytotoxic concentration: > 3000 nM
Compound 4: only a limit was reported (the forecaster's own chance of this, stated with the estimate: 80%); the middle value is on the limit's open side.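

In this assay compound 3 and compound 4 are both reported only as limits, so no step can be read between them: the limit of > 3000 nM in this assay, at which 2 of the 4 values shown sit.

The compounds shown leave open whether any of the four reaches a half-maximal cytotoxic concentration that can be read as a number in this assay, and whether cyclopentyl in place of butyl on a sulfur changes it at all.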